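The compounds below may be only part of what the source reports. "The series", "measured", "known", "first", "only" and "open" are said of these compounds alone.

Measured so far in a functional assay on Caco-2 cells (Homo sapiens), read by MTT assay, with a stated time of 48 h; a lower number here means a stronger inhibitor, a higher number a weaker inhibitor:
- compound 1 `CCn1c(C(=O)NCCCN(C)C)ccc1C(CC)(CC)c1ccc(OCC(O)C(C)(C)C)c(C)c1`: 1900 nM
- compound 2 `C=CCN(C)C(=O)c1ccc(C(CC)(CC)c2ccc(OCC(O)C(C)(C)C)c(C)c2)n1CC`: > 50000 nM (a limit, not a number)

Compound 2 has no number and stands at the limit of > 50000 nM in this assay, at which 1 of the 2 values shown sits. The next compound, compound 3 `CCn1c(C(=O)OCc2ccc(F)cc2)ccc1C(CC)(CC)c1ccc(OCC(O)C(C)(C)C)c(C)c1`, differs from it as follows: (4-fluorobenzyl)oxy in place of allyl(methyl)amino on a carbonyl carbon. In words, (4-fluorobenzyl)oxy comes in place of allyl(methyl)amino on a carbonyl carbon, so allyl(methyl)carbamoyl becomes ((4-fluorobenzyl)oxy)carbonyl.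

Among the measured compounds shown here, one measured step bears on this carbonyl carbon: an at least 26-fold higher number from compound 1 to compound 2 (1.42 log units; beyond the scatter). It is large and beyond the scatter, but it involves a different pair of groups and its size rests on a limit, so it is only a rough guide. Compound 3, like compound 2, lacks the (3-(dimethylamino)propyl)amino group of compound 1, whose 1900 nM is therefore not expected to be regained. No step beyond the scatter is expected in this assay, and the assay may again report only a limit. The expected step is an at least 1.2-fold lower number from compound 2 to compound 3 (0.09 log units; that floor lies within the scatter). Compound 3 is estimated at 40000 nM, with an expected range of 12000 nM to 80000 nM.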

Compound 3, half-maximal inhibitory concentration: > 50000 nM
Compound 3: no number, only a limit; the forecaster's own chance of this, stated with the estimate: 55%; middle value at least 1.2-fold (0.09 log units) from the limit.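

In this assay compound 3 gives > 50000 nM, which is a limit and not a number. Putting (4-fluorobenzyl)oxy in place of (3-(dimethylamino)propyl)amino on the carbonyl carbon gives an at least 26-fold higher number from compound 1 to compound 3 (1.42 log units; beyond the scatter), and allyl(methyl)amino in the same place gives an at least 26-fold higher number from compound 1 to compound 2 (1.42 log units; beyond the scatter), so the large loss is not particular to allyl(methyl)amino and also appears with an entering group that holds an aromatic ring and no nitrogen. The step between compound 2 and compound 3 cannot be read, and the two groups cannot be ranked against each other in this assay: the limit of > 50000 nM in this assay, at which 2 of the 3 values shown sit.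

Compound 2 and compound 3 both lack the amide hydrogen and the dimethylamino end of compound 1, so these two features are not separated by the compounds shown, and compound 1 remains the only one with a number. Open questions are what a plain propylamino, which keeps the amide hydrogen without the terminal amine, would give on this carbonyl carbon, and whether a shorter (2-(dimethylamino)ethyl)amino chain would hold the value of compound 1.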